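Swapping a Difluorobenzyl Group for a Chlorobenzyl Group

The source may hold more compounds than are shown below. What is called first, only, known or untested is meant among the compounds shown, and "the series" means these compounds.

Of the compounds shown here, two sharing one core have been tested in an in vitro assay on HEK293 cells for displacement of a labelled ligand from adenosine receptor A2b (Homo sapiens); on this read-out lower numbers stand for stronger inhibition and higher numbers for weaker inhibition. Compound 1 `CCCn1c(=O)c2nc(-c3cnn(Cc4ccc(F)cc4F)c3)[nH]c2n(CCC)c1=O` carries a 2,4-difluorobenzyl group on a ring nitrogen and gives 700 nM in this assay. Compound 2 `CC(C)Cn1c(=O)c2nc(-c3cnn(Cc4cccc(F)c4)c3)[nH]c2n(CC(C)C)c1=O` carries a 3-fluorobenzyl group together with branched side chains, and in this assay compound 2 gives 990 nM. These two numbers sit within the usual scatter of each other, so neither compound can be set apart from the other.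

Compound 3 `CCCn1c(=O)c2nc(-c3cnn(Cc4cccc(Cl)c4)c3)[nH]c2n(CCC)c1=O` is the next compound to be measured. It differs from compound 1 in one place: 3-chlorophenyl in place of 2,4-difluorophenyl on a saturated chain carbon bound to an aromatic nitrogen. Going by the values given here, no measured pair shows the effect of such a swap, so the direction of the step cannot be read from the data. The step of a 1.1-fold higher number from compound 1 to compound 3 (0.06 log units; within the scatter) is therefore expected to stay within the usual scatter. Compound 3 is estimated at 800 nM, within a range from 300 nM to 2200 nM.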

Compound 3, inhibition constant: 18 nM
Estimate against measurement, compound 3: 44-fold (1.65 log units) above, outside the stated range (below it).
By their numbers in this assay, from the lowest: compound 3; then compounds 1 and 2 (each within the scatter of the next).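

Going by these compounds alone, this position is far from silent: in this assay, exchanging the 2,4-difluorobenzyl group for a 3-chlorobenzyl group gives a 39-fold lower number from compound 1 to compound 3 (1.59 log units; beyond the scatter) as a large change, and the earlier compounds offered no pair that isolated this position. The swap changes the halogen, the number of halogen atoms and their placement on the ring all at once, so this single step cannot say which of these changes matters. No measurement here explains the step.

As far as these compounds go, it remains open whether the step comes from the chlorine itself or from where it sits on the ring; 2-chlorobenzyl, 4-chlorobenzyl and 3-bromobenzyl groups on the core of compound 3 could help separate these possibilities. From the compounds shown here alone, the effect of a 3-methoxybenzyl group or a benzyl group carrying an amine at this position also remains unknown.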